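Methyl to ethoxy on an aromatic carbon

A few compounds are considered here, and "the series" means these few. Any claim that something is new, unique, unknown or untested is made for them only; others in the source may bear on it.

Compound 1 `C=C(Br)C(=O)Nc1cccc(/C=C/C(=O)Nc2ccc(F)cc2)c1`: 13600 nM
Compound 2 `C=C(Br)C(=O)Nc1cccc(/C=C/C(=O)Nc2ccc(C)cc2)c1`: 2500 nM
Compound 3 `C=C(Br)C(=O)Nc1cccc(/C=C/C(=O)Nc2ccc(OCC)cc2)c1`: not yet measured

In a functional assay on MCF7 cells (Homo sapiens) for inhibition, read by MTT assay, with a stated time of 72 h (on this read-out higher numbers stand for weaker inhibition and lower numbers for stronger inhibition), compound 2 gives the lower of the two numbers, 2500 nM. Compound 3 differs from it by ethoxy in place of methyl on an aromatic carbon. Going by the values given here, only one measured step bears on this, a 5.4-fold lower number from compound 1 to compound 2 (0.74 log units; beyond the scatter), a modest change beyond the scatter with methyl in place of fluoro. It contains no ethoxy, so no step beyond the scatter is expected, in either direction. The expected step is a 1.1-fold higher number from compound 2 to compound 3 (0.05 log units; within the scatter). For compound 3 the estimated value is 2800 nM, with an expected range of 900 nM to 8000 nM.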

Compound 3, half-maximal inhibitory concentration: 5500 nM
Compound 3: the middle estimate sits 2.0-fold (0.29 log units) below what was measured; measured number inside the range.
By their numbers in this assay, from the lowest: compound 2; then compound 3; then compound 1.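

In this assay, swapping a small carbon group for a larger one at this position, para to a large group, is not neutral: there is a 2.2-fold higher number from compound 2 to compound 3 (0.34 log units; beyond the scatter) when ethoxy replaces methyl. Ethoxy still does better than fluoro, with a 2.5-fold lower number from compound 1 to compound 3 (0.39 log units; beyond the scatter) on that swap, so among these three groups methyl gives the lowest number and fluoro the highest. Nothing available here explains this order.
From the compounds shown here alone, it remains open where an amine, a carboxylic acid or a longer chain such as butoxy would fall in this order.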